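The compounds below may be only part of what the source reports. "The series", "measured", "known", "first", "only" and "open" are said of these compounds alone.

Compound 3 `CCN(Cc1cccn1C)C(=O)COc1ccc(C)cc1` stands second highest of the three numbers measured in an assay on HEK293 cells for agonist activity at transient receptor potential cation channel subfamily M member 8 (Homo sapiens), read by fluorescence and calcium flux, with a stated time of 15 min (a higher number here means that more compound is needed for the effect, a lower number that less compound is needed), where compound 3 gives 21300 nM. Compound 2 `CCN(Cc1cc[nH]c1)C(=O)COc1ccc(C)cc1` gives 21800 nM and compound 1 `CCN(Cc1ccoc1)C(=O)COc1ccc(C)cc1` gives 136 nM. The step of a 160-fold higher number from compound 1 to compound 3 (2.19 log units; beyond the scatter) was large, as was a 160-fold higher number from compound 1 to compound 2 (2.20 log units; beyond the scatter), while a 1.0-fold lower number from compound 2 to compound 3 (0.01 log units; within the scatter) lies within the scatter. Compound 4 `CCN(Cc1ccc(C)s1)C(=O)COc1ccc(C)cc1` differs from compound 3 by 5-methylthiophen-2-yl in place of 1-methyl-1H-pyrrol-2-yl on a saturated chain carbon bound to an amide-type nitrogen. Among the compounds with values here, no measured step exchanges a pyrrole for a thiophene, so the direction rests on the one ring swap that moved the number far, namely a 160-fold higher number from compound 1 to compound 3 (2.19 log units; beyond the scatter). A step of a 36-fold lower number from compound 3 to compound 4 (1.55 log units; beyond the scatter) is therefore expected, partly reversing that change. Compound 4 is estimated at 600 nM, between 100 nM and 6000 nM.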

Compound 4, half-maximal effective concentration: 178 nM
Beside the measured number, compound 4's estimate is 3.4-fold (0.53 log units) above it; low and high end bracket the measured number.
By their numbers in this assay, from the lowest: compounds 1 and 4 (each within the scatter of the next); then compounds 3 and 2 (each within the scatter of the next).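

Placed on a saturated chain carbon bound to an amide-type nitrogen, 5-methylthiophen-2-yl brings a 120-fold lower number from compound 3 to compound 4 (2.08 log units; beyond the scatter) and a 120-fold lower number from compound 2 to compound 4 (2.09 log units; beyond the scatter), so a change of ring alone at this place can recover most of what the pyrrole rings lost in this assay. Against furan-3-yl, the same group gives a 1.3-fold higher number from compound 1 to compound 4 (0.12 log units; within the scatter), so two different rings serve equally well here. Nothing measured here tells what lies behind these steps. The compounds shown leave open what the methyl group on the thiophene contributes, and how a plain thiophen-2-yl or a phenyl ring would behave at this place.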